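Series notes: hydroxyethyl analogue after the tetrahydropyranyl ether

The compounds below may be only part of what the source reports. "The series", "measured", "known", "first", "only" and "open" are said of these compounds alone.

Compound 1 `COc1ccc(F)cc1-c1cccc(-c2nn(CCCC#N)c(=O)o2)c1` gives 44% in a functional assay on the whole organism (strain Wistar albino) for inhibition, with Rattus norvegicus as the target, read by paw edema, with stated times of 30 min and 1 h, at a dose of 10 mg/kg by the oral route; a higher number here means more inhibition at the dose given (going by the name of the read-out), a lower number less inhibition. Compound 2 `COc1ccc(F)cc1-c1cccc(-c2nn(CCCCF)c(=O)o2)c1` gives 51% in this assay; between these two the data show a number 7 percentage points higher from compound 1 to compound 2 (within the scatter). Compound 3 `COc1ccc(F)cc1-c1cccc(-c2nn(CCOC3CCCCO3)c(=O)o2)c1` gives 32%, the lowest of the three numbers, reached by a number 12 percentage points lower from compound 1 to compound 3 (beyond the scatter) and by a number 19 percentage points lower from compound 2 to compound 3 (beyond the scatter). Compound 4 `COc1ccc(F)cc1-c1cccc(-c2nn(CCO)c(=O)o2)c1` differs from compound 3 at that same chain: hydrogen in place of oxan-2-yl on an oxygen on a saturated carbon. For the measured compounds named here, the steps that bear on this position are the two into compound 3, both modest and both downward, so in this assay a step of a number 10 percentage points higher from compound 3 to compound 4 (within the scatter) is expected, a partial return toward the earlier chain groups. Compound 4 is therefore estimated at 42%, with a range from 28% to 56%.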

Compound 4, a percentage reported as inhibition, in the whole organism at one dose (the size of the read-out at that dose, not a potency): 41%
Compound 4: the middle estimate sits 1 percentage points above what was measured; the measured number falls inside the stated range.
By their numbers in this assay, from the lowest: compounds 3, 4, 1 and 2 (each within the scatter of the next, the first and the last beyond it).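

In this assay the step from the tetrahydropyranyl ether to the free hydroxy reads a number 9 percentage points higher from compound 3 to compound 4 (within the scatter) and so does not separate the two chain ends. The 2-hydroxyethyl chain is also not separated from the other two chains, with a number 10 percentage points lower from compound 2 to compound 4 (within the scatter) and a number 3 percentage points lower from compound 1 to compound 4 (within the scatter) as its steps, whereas compound 3 stands beyond the scatter of both. Nothing at hand gives a reason for these numbers.

Still open, on these data alone, is whether an amine or a carboxylic acid at this chain end would separate from these chains. As far as these compounds go, a longer chain carrying the hydroxy is equally open.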